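Aryl substituent series: methyl to tert-butyl

This account rests on a few compounds, and the source may have more. Where it says the series, first, only, none or still open, it means among the compounds named here.

Measured compounds:
- compound 1 `O=C1C2=C(C(=O)c3ncccc31)C1(CS2)NC(=O)N(c2ccc([N+](=O)[O-])cc2)C1=O`: 8 nM
- compound 2 `O=C1C2=C(C(=O)c3ncccc31)C1(CS2)NC(=O)N(c2ccccc2)C1=O`: 25 nM
- compound 3 `Cc1ccc(N2C(=O)NC3(CSC4=C3C(=O)c3ncccc3C4=O)C2=O)cc1`: 27 nM

In a functional assay on MT4 cells (Homo sapiens) for antiproliferative activity, read by MTT assay, with a stated time of 96 h (on this read-out higher numbers stand for weaker inhibition and lower numbers for stronger inhibition), compound 3 carries the highest number of the three. Its nearest neighbour is compound 2, and a 1.1-fold higher number from compound 2 to compound 3 (0.03 log units; within the scatter) lies within the scatter, so the two cannot be ordered. The furthest is compound 1, with a 3.4-fold higher number from compound 1 to compound 3 (0.53 log units; beyond the scatter) beyond the scatter.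

The next step is tert-butyl in place of methyl on an aromatic carbon, giving compound 4 `CC(C)(C)c1ccc(N2C(=O)NC3(CSC4=C3C(=O)c3ncccc3C4=O)C2=O)cc1`. Among the measured compounds shown here, only one measured step bears on an alkyl group at this aromatic carbon: a 1.1-fold higher number from compound 2 to compound 3 (0.03 log units; within the scatter), which was within the scatter. The other steps, a 3.1-fold higher number from compound 1 to compound 2 (0.49 log units; beyond the scatter) and a 3.4-fold higher number from compound 1 to compound 3 (0.53 log units; beyond the scatter), concern removal of the nitro group and say nothing about alkyl size. Nothing measured here shows that a larger alkyl group moves the number, so the expectation is no step beyond the scatter, a 1.2-fold higher number from compound 3 to compound 4 (0.07 log units; within the scatter). Compound 4 is therefore estimated at 32 nM, with a range from 12 nM to 90 nM.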

Compound 4, half-maximal inhibitory concentration: 200 nM
Estimate against measurement, compound 4: 6.3-fold (0.80 log units) below; measured number above the stated range.
By their numbers in this assay, from the lowest: compound 1; then compounds 2 and 3 (each within the scatter of the next); then compound 4.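

In this assay, among the compounds shown here, 4-methylphenyl to 4-(tert-butyl)phenyl is the first alkyl change at this aromatic carbon to go beyond the scatter (a 7.4-fold higher number from compound 3 to compound 4 (0.87 log units; beyond the scatter)), whereas hydrogen to methyl had stayed within it, so the earlier result did not carry over to the larger alkyl group. For the compounds shown here, compound 4 also stands apart from the unsubstituted phenyl compound (an 8.0-fold higher number from compound 2 to compound 4 (0.90 log units; beyond the scatter)) and from the nitro compound (a 25-fold higher number from compound 1 to compound 4 (1.40 log units; beyond the scatter)), the latter being the only large step in the set. Nothing available here accounts for this rise in the number with tert-butyl.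

As far as these compounds go, whether the rise already appears with ethyl or isopropyl, or only with tert-butyl, remains open. Also open, from the compounds shown here alone, is where an amine or a methoxy group at this carbon would fall relative to the nitro and alkyl compounds.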